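The source may report more compounds than this note shows. Statements on the series, on what has been measured and on what is new or still open speak of the compounds shown alone.

Three compounds have numbers in an assay on isolated protein for inhibition of Fatty-acid amide hydrolase 1 (Homo sapiens); on this read-out higher numbers stand for weaker inhibition and lower numbers for stronger inhibition. Compound 1 `CCCCCCCC/C=C\CCCCCCC(=O)c1nnn(C)n1` gives 65 nM, and compound 2 `CCCCCCCC/C=C\CCCCCCC(=O)c1ncc(-c2ccccn2)o1` gives 18 nM; of these two numbers compound 1 holds the higher, and the gap to compound 2 lies beyond the scatter. Compound 3 `CCCCCCCC/C=C\CCCCCCC(=O)c1nc2ccc(C)cc2o1` reaches only the limit > 100000 nM, which is a boundary of the assay and not a number; this is the limit of > 100000 nM in this assay, at which 1 of the 3 values shown sits. Compound 4 `CCCCCCCC/C=C\CCCCCCC(=O)c1nccn1C` is not yet measured. It differs from compound 1 in one place: 1-methyl-1H-imidazol-2-yl in place of 2-methyl-2H-tetrazol-5-yl on a carbonyl carbon. For the measured compounds named here, no measured pair shows this change, so the expectation rests on the range the three compounds span. The step from compound 1 to compound 4 is expected to be a 4.6-fold higher number from compound 1 to compound 4 (0.66 log units; beyond the scatter), weakening inhibition. For compound 4 the estimate in this assay is 300 nM, between 60 nM and 2000 nM.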

Compound 4, inhibition constant: > 100000 nM
Compound 4 was reported as a limit; the forecaster's own chance of this, stated with the estimate: 5%; middle value at least 330-fold (2.52 log units) from the limit.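

In this assay, for the compounds shown here, this is the first pair that differs in one place, so the loss can be tied to the group on the carbonyl carbon: 1-methyl-1H-imidazol-2-yl in place of 2-methyl-2H-tetrazol-5-yl gives an at least 1500-fold higher number from compound 1 to compound 4 (3.18 log units; beyond the scatter). The value for compound 4 is a limit, not a number, and compound 3 stands at the same boundary: the limit of > 100000 nM in this assay, at which 2 of the 4 values shown sit.

Why these two rings differ so sharply cannot be read from a single pair. Going by these compounds, whether a methyl-substituted triazole on the same carbonyl carbon would keep inhibition or lose it remains open.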